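Fluorophenyl isomer swap on the ring nitrogen

A few compounds are considered here, and "the series" means these few. Any claim that something is new, unique, unknown or untested is made for them only; others in the source may bear on it.

Compound 3 `Nc1ccccc1NC(=O)c1ccc(CSC(=S)N2CCN(c3ccc(F)cc3)CC2)cc1` carries a 4-fluorophenyl on the amine nitrogen in a ring of the shared core. Among the measured compounds shown here, in a functional assay on HeLa cells (Homo sapiens) for antiproliferative activity, read by CCK-8 assay, with a stated time of 72 h, tested at 2 uM (on this read-out higher numbers stand for a stronger effect at the one concentration tested and lower numbers for a weaker effect), compound 3 gives 60.8%, the second highest of the three numbers known. Its nearest neighbour is compound 1 `Nc1ccccc1NC(=O)c1ccc(CSC(=S)N2CCN(c3ccc(Cl)cc3)CC2)cc1`, which in this assay gives 51.2%; the gap is a number 9.6 percentage points higher from compound 1 to compound 3 (within the scatter). The furthest is compound 2 `Nc1ccccc1NC(=O)c1ccc(CSC(=S)N2CCN(c3ccncc3)CC2)cc1`, which in this assay gives 77%; here a number 16.2 percentage points lower from compound 2 to compound 3 (beyond the scatter), and a number 25.8 percentage points higher from compound 1 to compound 2 (beyond the scatter).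

Compound 4 `Nc1ccccc1NC(=O)c1ccc(CSC(=S)N2CCN(c3ccccc3F)CC2)cc1` differs from compound 3 in one place: 2-fluorophenyl in place of 4-fluorophenyl on an amine nitrogen in a ring.

For the measured compounds named here, no measured step relocates the fluorine on the phenyl; the steps available exchange the whole group on the ring nitrogen. The closest in kind is the swap of one halophenyl for another, a number 9.6 percentage points higher from compound 1 to compound 3 (within the scatter), which stayed within the scatter, whereas exchanging a halophenyl for pyridin-4-yl gave the modest shifts a number 25.8 percentage points higher from compound 1 to compound 2 (beyond the scatter) and a number 16.2 percentage points lower from compound 2 to compound 3 (beyond the scatter). Since compound 4 keeps a fluorophenyl, a step no larger than the scatter is expected in this assay, direction uncertain. Compound 4 is therefore expected to give about 58%, within 40% to 75%. The implied step a number 2.8 percentage points lower from compound 3 to compound 4 (within the scatter) is expected to remain within the scatter.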

Compound 4, a percentage reported as inhibition, at one concentration (the size of the read-out at that concentration, not a potency): 17.5%
For compound 4 the middle estimate is 40.5 percentage points above the measured one; the measured number lies below the stated range.
By their numbers in this assay, from the lowest: compound 4; then compounds 1 and 3 (each within the scatter of the next); then compound 2.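

Moving the fluorine alone, with the same atoms joined differently, gives a number 43.3 percentage points lower from compound 3 to compound 4 (beyond the scatter) in this assay and is a larger step than any seen among compound 1, compound 2 and compound 3, where whole groups on the ring nitrogen were exchanged. Among the compounds shown here, the two halophenyl groups 4-chlorophenyl and 4-fluorophenyl had stayed within the scatter of each other, so the earlier compounds gave no sign that the placement of a halogen on this phenyl could matter so much. The other steps agree, with a number 33.7 percentage points lower from compound 1 to compound 4 (beyond the scatter) and a number 59.5 percentage points lower from compound 2 to compound 4 (beyond the scatter) leaving compound 4 as the lowest of the four, and no measurement shown offers a basis for explaining this.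

As far as these compounds go, whether the drop belongs to fluorine or to any group placed as in 2-fluorophenyl stays open, and 2-chlorophenyl, 2-methylphenyl and 2-methoxyphenyl on the same ring nitrogen would separate these cases, while 3-fluorophenyl would show how the effect runs between the two fluorophenyl isomers. From the compounds shown here alone, since each number comes from one concentration, the numbers show only a weaker effect of compound 4 at that concentration, and it stays open how its effect would compare at other concentrations.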